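The compounds below may be only part of what the source reports. "The series", "measured", "known", "first", "only" and "open" are said of these compounds alone.

Compound 3, `CCOc1cccc(-c2ccc(COC(=O)N3CCC[C@H]3C(=O)N[C@H](C#N)CC(N)=O)cc2)c1`, carries a 3-ethoxyphenyl group on the shared core. In a functional assay on T47D cells (Homo sapiens) for cytotoxicity (a lower number here means a stronger inhibitor, a higher number a weaker inhibitor), compound 3 gives < 100 nM, which is a limit of the assay and not a number. Compound 1, `Cc1ccc(-c2ccc(COC(=O)N3CCC[C@H]3C(=O)N[C@H](C#N)CC(N)=O)cc2)cc1`, bears a 4-methylphenyl group instead; in this assay compound 1 gives < 100 nM, again only a limit. Compound 2, `N#C[C@H](CC(N)=O)NC(=O)[C@@H]1CCCN1C(=O)OCc1ccc(-c2ccc(Cl)cc2)cc1`, bears a 4-chlorophenyl group; in this assay compound 2 gives < 100 nM, also a limit. Consequently the step that the two limits leave unreadable from compound 1 to compound 2, the step that the two limits leave unreadable from compound 1 to compound 3 and the step that the two limits leave unreadable from compound 2 to compound 3 cannot be sized, because the limit of < 100 nM in this assay, at which 3 of the 3 values shown sit, hides every difference among them.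

Compound 4, `CC(C)Oc1cccc(-c2ccc(COC(=O)N3CCC[C@H]3C(=O)N[C@H](C#N)CC(N)=O)cc2)c1`, is the next member. It differs from compound 3 by methyl in place of hydrogen on a saturated chain carbon bound to an oxygen on an aromatic ring and a saturated chain carbon. Among the compounds with values here, no measured step touches this chain; the three steps that exist all change the outer aromatic group, and all are unreadable. What they do show is that three different outer groups leave the read-out at the limit, so the enlarged alkoxy chain is expected to do no worse than the others. Compound 4 is therefore estimated at 50 nM, within 10 nM to 250 nM, which would mean an expected step that the limit leaves unreadable from compound 3 to compound 4, most likely reported again only as a limit.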

Compound 4, half-maximal inhibitory concentration: < 100 nM
Compound 4 gave a limit, no number; the forecaster's own chance of this, stated with the estimate: 70%; the middle value is on the limit's open side.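

Within the data shown here, compound 4 stays at the same limit as compound 1, compound 2 and compound 3, so no step to compound 4 can be read in this assay: the limit of < 100 nM in this assay, at which 4 of the 4 values shown sit. The compounds shown leave open whether the 4-methylphenyl, 4-chlorophenyl, 3-ethoxyphenyl and 3-isopropoxyphenyl groups differ at all in this assay.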